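The source may hold more compounds than are shown below. What is called first, only, known or untested is meant among the compounds shown, and "the series" means these compounds.

Compound 1 `Cc1cnc(Nc2ccc(S(C)(=O)=O)cc2)nc1Nc1nc2ccccc2s1` carries a methylsulfonyl group on an aromatic carbon, and in a functional assay on HeLa cells (Homo sapiens) for antiproliferative activity, read by MTT assay, with a stated time of 48 h (on this read-out higher numbers stand for weaker inhibition and lower numbers for stronger inhibition), compound 1 gives 460 nM. Compound 2 `Cc1cnc(Nc2ccc(Cl)cc2)nc1Nc1nc2ccccc2s1` carries chloro in that place. In this assay compound 2 reaches only the limit of > 50000 nM. Compound 3 `Cc1cnc(Nc2ccc(F)cc2)nc1Nc1nc2ccccc2s1` carries fluoro there. In this assay compound 3 likewise gives only the limit of > 50000 nM. Compound 3 thus stands at the weak end of what is shown, sitting at the limit of > 50000 nM in this assay, at which 2 of the 3 values shown sit.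

The change to compound 4 `Cc1cnc(Nc2ccc(N3CCCCC3)cc2)nc1Nc1nc2ccccc2s1` is piperidin-1-yl in place of fluoro on an aromatic carbon. The measured steps at this position are an at least 100-fold higher number from compound 1 to compound 3 (2.03 log units; beyond the scatter) and an at least 100-fold higher number from compound 1 to compound 2 (2.03 log units; beyond the scatter), while a step that the two limits leave unreadable from compound 2 to compound 3. Going by the values given here, none of them exchanges fluoro for piperidin-1-yl, so the new group has no measured counterpart, and the outcome is open. The step is estimated as an at least 16-fold lower number from compound 3 to compound 4 (1.22 log units; beyond the scatter), with a real chance that only a limit is returned. Compound 4 is expected to give about 3000 nM in this assay, estimated to lie between 300 nM and 30000 nM.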

Compound 4, half-maximal inhibitory concentration: 4340 nM
Beside the measured number, compound 4's estimate is 1.4-fold (0.16 log units) below it, and the stated range covers the measured number.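

Going by these compounds alone, until now methylsulfonyl was the only group at this place on the aromatic ring to give a readable number; piperidin-1-yl now does so too in this assay, with an at least 11-fold lower number from compound 3 to compound 4 (1.06 log units; beyond the scatter) and an at least 11-fold lower number from compound 2 to compound 4 (1.06 log units; beyond the scatter). The replacement of methylsulfonyl by this group is a smaller loss than the limits left by chloro and fluoro, though it is still a real one, with a 9.4-fold higher number from compound 1 to compound 4 (0.97 log units; beyond the scatter). Compound 2 and compound 3 remain limits and not numbers: the limit of > 50000 nM in this assay, at which 2 of the 4 values shown sit.

The compounds shown leave open whether this recovery depends on the ring of piperidin-1-yl or on its nitrogen, a question that a dimethylamino group or a cyclohexyl group would separate. They also leave open how a morpholin-4-yl group or a carboxylic acid at this place would compare with methylsulfonyl.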